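Trimethoxyphenyl for chlorophenyl on a chalcone core

The compounds below may be only part of what the source reports. "The series", "measured", "known", "first", "only" and "open" are said of these compounds alone.

Compound 1 `COc1cc(/C=C/C(=O)c2cccc(-n3cc(-c4ccc(Cl)cc4)[nH]c3=O)c2)cc(OC)c1OC`: "not active" (no number reported)
Compound 2 `O=C(/C=C/c1cccc(O)c1)c1cccc(-n2cc(-c3ccc(Cl)cc3)[nH]c2=O)c1`: 3550 nM

In a functional assay on A549 cells (Homo sapiens) for inhibition (a lower number here means a stronger inhibitor of growth, a higher number a weaker inhibitor of growth), compound 1 gives "not active" (no number reported), so no single number marks where it stands. Compound 2, a different chalcone on the same core, gives 3550 nM in this assay. Compound 3 `COc1cc(/C=C/C(=O)c2cccc(-n3cc(-c4cc(OC)c(OC)c(OC)c4)[nH]c3=O)c2)cc(OC)c1OC` arises from compound 1 by one change: 3,4,5-trimethoxyphenyl in place of 4-chlorophenyl on an aromatic carbon. Within the data shown here, no measured pair shows this exchange, so its effect is unknown; with compound 1 giving no number, the step is expected to leave compound 3 weak, perhaps without a reported number at all. Compound 3 is estimated at 9000 nM, within 2500 nM to 40000 nM.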

Compound 3, concentration for 50% growth inhibition: 3030 nM
Compound 3: the middle estimate sits 3.0-fold (0.47 log units) above what was measured; low and high end bracket the measured number.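

Compound 1 has no number to set against compound 3, and no step can be read between them. Going by these compounds, how far 3,4,5-trimethoxyphenyl in place of 4-chlorophenyl shifts growth inhibition stays open. Nothing here offers an explanation.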